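This account rests on a few compounds, and the source may have more. Where it says the series, first, only, none or still open, it means among the compounds named here.

Compound 1 `O=C(Nc1cccc(-n2cc(-c3ccncc3)c(-c3cc(O)cc(Cl)c3)n2)c1)Nc1ccc(Cl)c(C(F)(F)F)c1` gives -74% in a functional assay on KM12 cells (Homo sapiens) for inhibition, read by sulforhodamine B assay, with a stated time of 48 h, tested at 100 uM (on this read-out lower numbers stand for a stronger effect and higher numbers for a weaker effect at the one concentration tested), the lowest of the two numbers recorded. Compound 2 `O=C(Nc1cccc(-n2cc(-c3ccncc3)c(-c3cc(O)cc(Cl)c3)n2)c1)Nc1ccc(Cl)c(Cl)c1` gives -63% there, and the step of a number 11 percentage points higher from compound 1 to compound 2 (beyond the scatter) is the only measured one. Compound 3 `COc1cc(Cl)cc(-c2nn(-c3cccc(NC(=O)Nc4ccc(Cl)c(C(F)(F)F)c4)c3)cc2-c2ccncc2)c1` arises from compound 1 by methyl in place of hydrogen on an oxygen on an aromatic ring. No measured step touches that oxygen, so nothing shown speaks to its size or direction; the one step concerns a different ring. The expectation for compound 3 is therefore a step of a number 6 percentage points higher from compound 1 to compound 3 (within the scatter) of no clear size, and compound 3 is estimated at -68%, within -95% to -20%.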

Compound 3, a percentage reported as activity, at one concentration (the size of the read-out at that concentration, not a potency): -70%
Compound 3: middle estimate off by 2 percentage points, on the high side; low and high end bracket the measured number.
By their numbers in this assay, from the lowest: compounds 1, 3 and 2 (each within the scatter of the next, the first and the last beyond it).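

Among the compounds shown here, replacing hydrogen with methyl on the oxygen, hydroxy to methoxy, gives a number 4 percentage points higher from compound 1 to compound 3 (within the scatter) in this assay and is the first measured change at this position. At the one concentration tested, the read-out therefore does not depend on keeping the hydrogen on that oxygen. Nothing available explains this result.

Open, from the compounds shown here alone, is whether a longer chain on that oxygen, or an amine or a carboxylic acid in place of the hydroxy, would read the same. Also open, going by these compounds, is whether the methoxy behaves alike on the dichlorophenyl urea of compound 2.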